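A few compounds are considered here, and "the series" means these few. Any claim that something is new, unique, unknown or untested is made for them only; others in the source may bear on it.

- Compound 1 `O=C1C(=Cc2ccc(Cl)cc2)C(=O)N(c2ccc(Cl)cc2)N1c1ccc(Cl)cc1`: 32600 nM
- Compound 2 `COc1ccc(C=C2C(=O)N(c3ccc(Cl)cc3)N(c3ccc(Cl)cc3)C2=O)cc1`: > 128000 nM

In a functional assay on MGC-803 cells (Homo sapiens) for cytotoxicity, read by MTT assay, with a stated time of 72 h (a higher number here means a weaker inhibitor, a lower number a stronger inhibitor), compound 2 stands at the limit of > 128000 nM in this assay, at which 1 of the 2 values shown sits, which is a limit and not a number. Compound 3 `COc1ccc(C=C2C(=O)N(c3ccc(Cl)cc3)N(c3ccc(Cl)cc3)C2=O)cc1OC` carries methoxy in place of hydrogen on an aromatic carbon, taking 4-methoxyphenyl to 3,4-dimethoxyphenyl. Among the compounds with values here, the only measured step, an at least 3.9-fold higher number from compound 1 to compound 2 (0.59 log units; beyond the scatter), also introduced a methoxy, there in place of chloro, and it weakened the compound beyond the scatter. On that single step, no gain in strength and no change beyond the scatter is expected. The estimated step is an at least 1.0-fold lower number from compound 2 to compound 3 (0.02 log units; that floor lies within the scatter). For compound 3 the expected value is 120000 nM, with an estimated range of 50000 nM to 250000 nM.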

Compound 3, half-maximal inhibitory concentration: > 128000 nM
Compound 3: only a limit was reported; the forecaster's own chance of this, stated with the estimate: 60%; middle value at least 1.0-fold (0.02 log units) from the limit.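

The step from 4-methoxyphenyl to 3,4-dimethoxyphenyl cannot be read in this assay, because compound 2 and compound 3 are each given only as a limit: the limit of > 128000 nM in this assay, at which 2 of the 3 values shown sit. What is new is that 3,4-dimethoxyphenyl in place of 4-chlorophenyl brings an at least 3.9-fold higher number from compound 1 to compound 3 (0.59 log units; beyond the scatter). A second methoxy on this ring therefore does not bring the value back to that of compound 1.

On these data alone, it remains open whether an amine or a carboxylic acid on this ring would give a value that can be read, and how a single chloro group at this new position would compare.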